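The source may report more compounds than this note shows. Statements on the series, on what has been measured and on what is new or still open speak of the compounds shown alone.

Measured in a functional assay on HepG2 cells (Homo sapiens) for cytotoxicity, read by MTT assay, with a stated time of 72 h; on this read-out higher numbers stand for weaker inhibition of growth and lower numbers for stronger inhibition of growth:

Compound 1 `CS/C(=N\C(=O)c1cc2ccccc2s1)NC(=O)c1cc2ccccc2s1` gives 53000 nM.
Compound 2 `O=C(/N=C(/NC(=O)c1cc2ccccc2s1)[Se]Cc1ccccc1)c1cc2ccccc2s1` gives 49000 nM.
Compound 3 `CS/C(=N\C(=O)c1cnc2ccccc2c1)NC(=O)c1cnc2ccccc2c1` gives only a limit of the assay, > 100000 nM.

Compound 1 and compound 2 differ by a group of 8 heavy atoms (7 carbon, 1 selenium; one six-membered aromatic ring of carbon only) in place of a group of 2 heavy atoms (1 carbon, 1 sulfur; no ring), on a carbon with a double bond to nitrogen. The step is a 1.1-fold lower number from compound 1 to compound 2 (0.03 log units; within the scatter), so the two values are indistinguishable. The difference between the core of compound 1 and the core of compound 3 is not broken down here.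

Compound 4 `O=C(/N=C(/NC(=O)c1cnc2ccccc2c1)[Se]Cc1ccccc1)c1cnc2ccccc2c1` is not yet measured. It differs from compound 3 by a group of 8 heavy atoms (7 carbon, 1 selenium; one six-membered aromatic ring of carbon only) in place of a group of 2 heavy atoms (1 carbon, 1 sulfur; no ring), on a carbon with a double bond to nitrogen, the same change as that from compound 1 to compound 2, at the same place.

For compound 4 a step that the limit leaves unreadable from compound 3 to compound 4 in this assay is expected, resting on a 1.1-fold lower number from compound 1 to compound 2 (0.03 log units; within the scatter). Since compound 3 sits at the limit of > 100000 nM in this assay, at which 1 of the 3 values shown sits, compound 4 is expected to land at or near that limit as well. Compound 4 is estimated at 150000 nM, between 70000 nM and 400000 nM.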

Compound 4, concentration for total growth inhibition: 48900 nM
For compound 4 the middle estimate is 3.1-fold (0.49 log units) above the measured one; measured number below the stated range.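

In this assay the exchange of methylsulfanyl for the selenium-bearing group with its six-membered aromatic ring gives an at least 2.0-fold lower number from compound 3 to compound 4 (0.31 log units; beyond the scatter) on one core, against a 1.1-fold lower number from compound 1 to compound 2 (0.03 log units; within the scatter) on the other. As far as these compounds go, for compound 3 the assay gives only the limit > 100000 nM and no number, so the full size of the first step stays unknown. The series therefore shows no clear transfer of the change between the cores, and equally no proven difference: the same change on two cores in this assay, a 1.1-fold lower number (0.03 log units; within the scatter) from compound 1 to compound 2 and an at least 2.0-fold lower number (0.31 log units; beyond the scatter) from compound 3 to compound 4; the limit leaves it open whether they differ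

The compounds shown do not separate the selenium from the ring, which a benzylsulfanyl group on the same carbon would do. Also open, from the compounds shown here alone, is how an amine or a longer chain at that place would compare with methylsulfanyl on either core.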